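Benzyl in place of 3-fluorophenyl: an expected dose

The source may report more compounds than this note shows. Statements on the series, on what has been measured and on what is new or still open speak of the compounds shown alone.

Measured compounds:
Compound 1, `CCCCCCOc1ccc(-n2cnnc2CCCCC)cc1`, gives 32.8 mg/kg in a functional assay on the whole organism (strain C57B/6) with Mus musculus as the target, in the maximal electroshock model; on this read-out higher numbers stand for an effect only at larger amounts of compound and lower numbers for an effect already at smaller amounts.
Compound 2, `CCCCCCOc1ccc(-n2cnnc2CCCCCC)cc1`, gives > 40 mg/kg, which is a limit of the assay and not a number.
Compound 3, `CCCCCCOc1ccc(-n2cnnc2-c2cccc(F)c2)cc1`, gives 27.4 mg/kg.

Of the two numbers shown, compound 3 gives the lowest, and its nearest neighbour is compound 1: a 1.2-fold lower number from compound 1 to compound 3 (0.08 log units; within the scatter), within the scatter. Compound 4, `CCCCCCOc1ccc(-n2cnnc2Cc2ccccc2)cc1`, is not yet measured; it differs from compound 3 by benzyl in place of 3-fluorophenyl on an aromatic carbon. Among the compounds with values here, two measured steps bear on this change, both exchanging a pentyl or hexyl chain for the 3-fluorophenyl: a 1.2-fold lower number from compound 1 to compound 3 (0.08 log units; within the scatter) and an at least 1.4-fold lower number from compound 2 to compound 3 (0.16 log units; that floor lies within the scatter), neither beyond the scatter. Within the data shown here, no measured step exchanges an aryl group for a benzyl group, so the expectation rests on the narrow spread of the three values. The step expected from this change is a 1.1-fold higher number from compound 3 to compound 4 (0.04 log units; within the scatter). The estimated dose for compound 4 is 30 mg/kg, between 15 mg/kg and 60 mg/kg.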

Compound 4, dose for half-maximal effect: 19 mg/kg
For compound 4 the middle estimate is 1.6-fold (0.20 log units) above the measured one; the range from low to high includes it.
By their numbers in this assay, from the lowest: compounds 4, 3 and 1 (each within the scatter of the next). At a limit, above all of these: compound 2.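

Benzyl on this aromatic carbon, between two ring nitrogen atoms, keeps the dose level with the 3-fluorophenyl and pentyl compounds in this assay, with a 1.4-fold lower number from compound 3 to compound 4 (0.16 log units; within the scatter) and a 1.7-fold lower number from compound 1 to compound 4 (0.24 log units; within the scatter). The earlier compounds shown here showed no step beyond the scatter, but benzyl gives the first one, set against the hexyl chain of compound 2, whose value is a limit and not a number, with an at least 2.1-fold lower number from compound 2 to compound 4 (0.32 log units; beyond the scatter). That step rests on a limit: the limit of > 40 mg/kg in this assay, at which 1 of the 4 values shown sits.

Still open, from the compounds shown here alone, is how an amine or a carboxylic acid on the phenyl of the benzyl group, or a longer chain carrying that phenyl, would change the dose.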